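Swapping fluoro for methoxy on an unmeasured compound

The compounds below may be only part of what the source reports. "The series", "measured", "known", "first", "only" and "open" are said of these compounds alone.

Compound 1 `COC(=O)N1Cc2c(ccc(C)c2C)C(c2ccccc2)C1`: "not determined" (no result reported)
Compound 2 `Cc1ccc2c(c1C)CN(C(=O)N(C)C)CC2c1cccc(Cl)c1`: 3020 nM
Compound 3 `CN(C)C(=O)N1Cc2c(F)cccc2C(c2cccc(O)c2)C1`: "not determined" (no result reported)

In a functional assay on A2780 cells (Homo sapiens) for antiproliferative activity (a lower number here means a stronger inhibitor, a higher number a weaker inhibitor), only compound 2 has a number. Compound 3 has no reported result, and neither does compound 1, so there is no starting value for the next step. Compound 4 `COc1cccc2c1CN(C(=O)N(C)C)CC2c1cccc(O)c1` arises through a single change: methoxy in place of fluoro on an aromatic carbon, ortho to a fused ring and meta to a fused ring. Going by the values given here, no measured pair shows what this swap does, so the expected step in this assay is none beyond the scatter, with no direction favoured. Among the compounds with values here, the only guide is compound 2 at 3020 nM, which differs from compound 4 in more than one place, so the range stays wide. The estimated value for compound 4 is 2500 nM, expected to lie between 400 nM and 15000 nM.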

Compound 4, half-maximal inhibitory concentration: 332 nM
Estimate against measurement, compound 4: 7.5-fold (0.88 log units) above; measured number outside the range, below it.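

Going by these compounds alone, compound 3 has no single number in this assay, so no step to compound 4 can be read. The compounds shown leave open what methoxy in place of fluoro does to potency. No measured evidence bears on this result.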